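Amide substituent variation on the shared core

The source may hold more compounds than are shown below. What is called first, only, known or untested is meant among the compounds shown, and "the series" means these compounds.

Among the measured compounds shown here, compound 3 `O=C(O)c1ccc2noc(-c3ccc(NC(=O)C4CCCC4)cc3)c2c1` gives 190 nM in an assay for inhibition of inositol hexakisphosphate kinase 2 (Homo sapiens), read by colorimetric assay, coupled enzyme assay and malachite green, with a stated time of 120 min, in the presence of a further agent that is not named here (on this read-out lower numbers stand for stronger inhibition and higher numbers for weaker inhibition), the lowest of the three numbers measured so far. Compound 2 `O=C(O)c1ccc2noc(-c3ccc(N4CCCC4=O)cc3)c2c1` gives 480 nM and compound 1 `CC(C)C(=O)Nc1ccc(-c2onc3ccc(C(=O)O)cc23)cc1` gives 820 nM; the steps of a 2.5-fold lower number from compound 2 to compound 3 (0.40 log units; beyond the scatter) and a 4.3-fold lower number from compound 1 to compound 3 (0.64 log units; beyond the scatter) both run toward compound 3. Compound 4 `O=C1CCC(C(=O)Nc2ccc(-c3onc4ccc(C(=O)O)cc34)cc2)CN1` carries a group of 7 heavy atoms (5 carbon, 1 nitrogen, 1 oxygen; one six-membered non-aromatic ring with 1 hetero atom) in place of a group of 5 heavy atoms (5 carbon; one five-membered non-aromatic ring of carbon only), on a carbonyl carbon. For the measured compounds named here, the only measured step at the same place is a 4.3-fold lower number from compound 1 to compound 3 (0.64 log units; beyond the scatter), where a larger carbon ring gave a modestly lower number; no measured step brings a ring with a hetero atom to that carbonyl carbon, so guidance is weak. For compound 4 a step of about a 2.1-fold higher number from compound 3 to compound 4 (0.32 log units; beyond the scatter) is expected, toward a somewhat higher number, possibly within the scatter. For compound 4 a value of 400 nM is estimated, with a range from 120 nM to 1300 nM.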

Compound 4, half-maximal inhibitory concentration: 2390 nM
Beside the measured number, compound 4's estimate is 6.0-fold (0.78 log units) below it; the whole stated range lies below it.
By their numbers in this assay, from the lowest: compound 3; then compounds 2 and 1 (each within the scatter of the next); then compound 4.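

At this carbonyl carbon, a larger group does not keep lowering the number: the cyclopentyl gain over isopropyl reverses with the six-membered ring carrying a hetero atom, giving a 13-fold higher number from compound 3 to compound 4 (1.10 log units; beyond the scatter). The same group also falls short of the small open-chain isopropyl, with a 2.9-fold higher number from compound 1 to compound 4 (0.46 log units; beyond the scatter). No measurement shown here accounts for this rise.

From the compounds shown here alone, it remains open whether the higher number follows the six-membered ring itself or its ring nitrogen and carbonyl. A cyclohexyl group on the same carbonyl carbon would separate these two readings.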